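The source may hold more compounds than are shown below. What is called first, only, known or untested is meant among the compounds shown, and "the series" means these compounds.

Three benzoate esters of the shared core have been run in a functional assay on U-251 cells (Homo sapiens) for antiproliferative activity, read by sulforhodamine B assay, with a stated time of 48 h, tested at 50 uM; a lower number here means less inhibition, a higher number more inhibition at the concentration tested (going by the name of the read-out). Compound 1 `CC1=CC[C@H](C(C)C)c2cc(C)c(OC(=O)c3ccc(C)cc3)cc21` gives 67.7% in this assay, the second highest of the three numbers; compound 3 `Cc1cc2c(C(C)C)ccc(C)c2cc1OC(=O)c1ccc([N+](=O)[O-])cc1` gives 100%, while compound 2 `Cc1cc2c(C(C)C)ccc(C)c2cc1OC(=O)c1ccc(C(F)(F)F)cc1` gives 16.5%. Within the data shown here, the only single-change step measured so far, a number 83.5 percentage points higher from compound 2 to compound 3 (beyond the scatter), is large and well beyond the scatter. Compound 4 `CC1=CC[C@H](C(C)C)c2cc(C)c(OC(=O)c3cccc([N+](=O)[O-])c3)cc21` differs from compound 1 by 3-nitrophenyl in place of 4-methylphenyl on a carbonyl carbon. Among the measured compounds shown here, no measured step covers this exact exchange: the step from compound 2 to compound 3 puts nitro in place of trifluoromethyl, whereas here 3-nitrophenyl replaces 4-methylphenyl. Given that the nitro-bearing compound 3 reaches 100%, an upward step a number 17.3 percentage points higher from compound 1 to compound 4 (beyond the scatter) is expected for compound 4, with the unmatched pairing leaving the size uncertain. Compound 4 is therefore estimated at 85%, within 55% to 100%.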

Compound 4, a percentage reported as inhibition, at one concentration (the size of the read-out at that concentration, not a potency): 44%
Beside the measured number, compound 4's estimate is 41 percentage points above it; measured number below the stated range.
By their numbers in this assay, from the lowest: compound 2; then compound 4; then compound 1; then compound 3.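

In this assay, 3-nitrophenyl in place of 4-methylphenyl on the carbonyl carbon lowers the number (a number 23.7 percentage points lower from compound 1 to compound 4 (beyond the scatter)), so a nitro-bearing ring at this place does not by itself raise inhibition on the core of compound 1. This step runs in the opposite direction to the other nitro step (a number 83.5 percentage points higher from compound 2 to compound 3 (beyond the scatter)), although the two exchange different groups on different cores. No available evidence bears on the reason for this fall.

Still open, going by these compounds, is whether the same exchange would lower the number on the core of compound 2. On these data alone, the effect of an amine or a carboxylic acid on the phenyl ring at this place also remains open.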